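Pyrrolidin-1-yl for dimethylamino on compound 3

This account rests on a few compounds, and the source may have more. Where it says the series, first, only, none or still open, it means among the compounds named here.

- compound 1 `CCN(CC)CC(=O)OC1CC2(N(C)C)CC(c3ccccc3)C1C(c1ccccc1)C2` gives 30100 nM
- compound 2 `CCN(CC)CC(=O)OC1CC2(N3CCCC3)CC(c3ccccc3)C1C(c1ccccc1)C2` gives 49000 nM
- compound 3 `CN(C)C12CC(OC(=O)CN3CCCC3)C(C(c3ccccc3)C1)C(c1ccccc1)C2` gives 32700 nM

These values come from an ADME assay on L6 cells (Rattus norvegicus) for cytotoxicity (a lower number here means a stronger inhibitor, a higher number a weaker inhibitor), and all three lie close together. Compound 3 cannot be told apart from compound 1, as a 1.1-fold higher number from compound 1 to compound 3 (0.04 log units; within the scatter) shows, and its gap to compound 2 also lies within the usual scatter.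

The untested compound 4 `O=C(CN1CCCC1)OC1CC2(N3CCCC3)CC(c3ccccc3)C1C(c1ccccc1)C2` differs from compound 3 in one place, on a saturated ring carbon: pyrrolidin-1-yl in place of dimethylamino on a saturated ring carbon is the whole change. The same swap links two measured compounds, and a 1.6-fold higher number from compound 1 to compound 2 (0.21 log units; within the scatter) is the closest guide. The other measured step, a 1.1-fold higher number from compound 1 to compound 3 (0.04 log units; within the scatter), concerns the chain carbon bound to a carbonyl carbon, a change compound 3 already carries.

In this assay a small rise in the number is therefore expected, with nothing beyond the scatter. The expected change is a 1.5-fold higher number from compound 3 to compound 4 (0.17 log units; within the scatter) in this estimate. For compound 4 the estimated value is 48000 nM with an expected range from 27000 nM to 85000 nM in repeat measurements.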

Compound 4, half-maximal inhibitory concentration: 42900 nM
Beside the measured number, compound 4's estimate is 1.1-fold (0.05 log units) above it; low and high end bracket the measured number.
By their numbers in this assay, from the lowest: compounds 1, 3, 4 and 2 (each within the scatter of the next).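

In this assay, pyrrolidin-1-yl in place of dimethylamino on the saturated ring carbon gives a 1.3-fold higher number from compound 3 to compound 4 (0.12 log units; within the scatter), so this swap now has a second core behind it, and on neither core can its step be told from the scatter: the same change on two cores in this assay, a 1.6-fold higher number (0.21 log units; within the scatter) from compound 1 to compound 2 and a 1.3-fold higher number (0.12 log units; within the scatter) from compound 3 to compound 4, 1.2-fold (0.09 log units) apart, within the scatter of two such steps
The other swap, pyrrolidin-1-yl in place of diethylamino on the saturated chain carbon bound to a carbonyl carbon, gives a 1.1-fold lower number from compound 2 to compound 4 (0.06 log units; within the scatter), and it too now has a second core behind it: the same change on two cores in this assay, a 1.1-fold higher number (0.04 log units; within the scatter) from compound 1 to compound 3 and a 1.1-fold lower number (0.06 log units; within the scatter) from compound 2 to compound 4, 1.2-fold (0.09 log units) apart, within the scatter of two such steps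
Among these four compounds, neither place yields a step beyond the scatter, even in compound 4, which carries pyrrolidin-1-yl at both.

Going by these compounds, it remains open whether morpholin-4-yl or a primary amine on the saturated ring carbon would give a step beyond the scatter. The same question stands for a carboxylic acid in place of the amine on the chain carbon.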